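Amide aryl variation on the shared core: toward compound 4

This account rests on a few compounds, and the source may have more. Where it says the series, first, only, none or still open, it means among the compounds named here.

Measured so far in a functional assay on A549 cells (Homo sapiens) for antiproliferative activity, read by CCK-8 assay, with a stated time of 72 h; on this read-out lower numbers stand for stronger inhibition and higher numbers for weaker inhibition:
compound 1, `O=C(Nc1cccc(-c2oc3cc(-c4ccc(F)cc4)ccc3c(=O)c2O)c1)c1ccc(C(F)(F)F)cc1`, gives 19400 nM
compound 2, `Cc1cccc(C(=O)Nc2cccc(-c3oc4cc(-c5ccc(F)cc5)ccc4c(=O)c3O)c2)c1`, gives 16500 nM
compound 3, `COc1cc(OC)cc(C(=O)Nc2cccc(-c3oc4cc(-c5ccc(F)cc5)ccc4c(=O)c3O)c2)c1`, gives 2390 nM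

Compound 3 has the lowest number of the three in this assay; its steps to compound 2 and compound 1 are both beyond the scatter, so it stands as the most potent of the measured set. The two other amide aryl groups sit close together: a 1.2-fold lower number from compound 1 to compound 2 (0.07 log units; within the scatter). Exchanging either of them for the 3,5-dimethoxyphenyl group gave a modest gain: an 8.1-fold lower number from compound 1 to compound 3 (0.91 log units; beyond the scatter) and a 6.9-fold lower number from compound 2 to compound 3 (0.84 log units; beyond the scatter).

Compound 4, `O=C(Nc1cccc(-c2oc3cc(-c4ccc(F)cc4)ccc3c(=O)c2O)c1)c1cnc(Cl)nc1Cl`, carries the change (2,4-dichloropyrimidin-5-yl in place of 3,5-dimethoxyphenyl on a carbonyl carbon). Among the measured compounds shown here, no measured pair bears directly on this group; the only evidence is that the 3,5-dimethoxyphenyl group of compound 3 stands apart from the other two aryl amides, while 4-(trifluoromethyl)phenyl and 3-methylphenyl lie together near the weaker end. A fresh aryl group is therefore expected to fall back toward the level of compound 1 and compound 2 rather than to hold the level of compound 3, giving an expected step of a 2.9-fold higher number from compound 3 to compound 4 (0.47 log units; beyond the scatter) in this assay. For compound 4 the estimate in this assay is 7000 nM, with a range from 1500 nM to 30000 nM.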

Compound 4, half-maximal inhibitory concentration: > 100000 nM
Compound 4: no number, only a limit; the forecaster's own chance of this, stated with the estimate: 10%; middle value at least 14-fold (1.15 log units) from the limit.
By their numbers in this assay, from the lowest: compound 3; then compounds 2 and 1 (each within the scatter of the next). At a limit, above all of these: compound 4.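

In this assay, compound 4 gives only a limit and no number: the limit of > 100000 nM in this assay, at which 1 of the 4 values shown sits. The earlier compounds shown here showed this amide position moving the read-out only within a measurable range, whereas the 2,4-dichloropyrimidin-5-yl group gives an at least 41-fold higher number from compound 3 to compound 4 (1.62 log units; beyond the scatter). It also stands clear of the two weaker aryl amides, with an at least 6.0-fold higher number from compound 2 to compound 4 (0.78 log units; beyond the scatter) and an at least 5.1-fold higher number from compound 1 to compound 4 (0.71 log units; beyond the scatter), and all three steps are minimum sizes set by that limit.

Still open, on these data alone, is whether the ring nitrogens or the chlorine atoms carry the loss; a 3,5-dichlorophenyl group or an unsubstituted pyrimidin-5-yl group on the same carbonyl would separate the two. Also open, as far as these compounds go, is whether compound 3 needs both methoxy groups, a question that a single 3-methoxyphenyl group would address.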